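This account rests on a few compounds, and the source may have more. Where it says the series, first, only, none or still open, it means among the compounds named here.

Compound 1, `N=C(NCCCc1c[nH]cn1)NCCC(c1ccc(C(F)(F)F)cc1)c1ccccn1`, gives 282 nM in a functional assay on ileum for antagonist activity at histamine H1 receptor (Cavia porcellus); a higher number here means weaker binding, a lower number tighter binding.
Compound 2, `N=C(NCCCc1c[nH]cn1)NCCC(c1ccccn1)c1ccccc1F`, gives 437 nM in this assay.
Compound 3, `N=C(NCCCc1c[nH]cn1)NCCC(c1ccc(F)c(F)c1)c1ccccn1`, gives 85.1 nM in this assay.

Compound 3 has the lowest of the three numbers. Its nearest neighbour is compound 1: the step of a 3.3-fold lower number from compound 1 to compound 3 (0.52 log units; beyond the scatter). The furthest is compound 2: the step of a 5.1-fold lower number from compound 2 to compound 3 (0.71 log units; beyond the scatter). Between the other two the step of a 1.5-fold higher number from compound 1 to compound 2 (0.19 log units; within the scatter), so those two cannot be told apart.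

Compound 4, `N=C(NCCCc1c[nH]cn1)NCCC(c1cc(F)cc(F)c1)c1ccccn1`, differs from compound 3 by 3,5-difluorophenyl in place of 3,4-difluorophenyl on a saturated chain carbon bound to an aromatic carbon and a saturated chain carbon. Among the measured compounds shown here, no measured step exchanges one difluorophenyl for another. The two steps that bear on it are a 3.3-fold lower number from compound 1 to compound 3 (0.52 log units; beyond the scatter) and a 5.1-fold lower number from compound 2 to compound 3 (0.71 log units; beyond the scatter), both arriving at compound 3, both modest and both beyond the scatter; they show that the substituents on this phenyl ring move the number, but neither says in which direction a shift of one fluorine will go. The step from compound 3 to compound 4 is therefore expected to be small, most likely within the scatter or a modest rise, a 1.6-fold higher number from compound 3 to compound 4 (0.22 log units; within the scatter). For compound 4 the number in this assay is estimated at 140 nM, with a range from 50 nM to 400 nM.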

Compound 4, dissociation constant: 275 nM
Estimate against measurement, compound 4: 2.0-fold (0.29 log units) below; the measured number falls inside the stated range.
By their numbers in this assay, from the lowest: compound 3; then compounds 4, 1 and 2 (each within the scatter of the next).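

Among these compounds, the exchange of 3,5-difluorophenyl for 3,4-difluorophenyl is the only change that leaves the atoms the same and alters only how they are joined, and it is enough to shift the result in this assay (a 3.2-fold higher number from compound 3 to compound 4 (0.51 log units; beyond the scatter)). The number at this position therefore depends on where the two fluorines stand on the phenyl ring, not merely on their presence, and compound 4 goes against any reading that difluorophenyl groups as such give the lower number. Compound 4 cannot be told apart from the two earlier compounds (a 1.0-fold lower number from compound 1 to compound 4 (0.01 log units; within the scatter); a 1.6-fold lower number from compound 2 to compound 4 (0.20 log units; within the scatter)), which leaves compound 3, whose steps to all three others lie beyond the scatter, as the only one that stands apart, with the tightest binding of the four.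

On these data alone, whether 3,4-difluorophenyl is unusual at this place, or whether a dichlorophenyl group, a methoxyphenyl group or an unsubstituted phenyl group would give a similarly low number, remains open. Nothing in the data shown accounts for the difference between the two difluorophenyl groups.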